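Aryl swap on the ring nitrogen: towards compound 3

The source may report more compounds than this note shows. Statements on the series, on what has been measured and on what is new or still open speak of the compounds shown alone.

Among the measured compounds shown here, compound 2 `COc1ccc(-n2nc(C(=O)Nc3ccc(Oc4ccnc5cc(OCCCN6CCC(C)CC6)c(OC)cc45)c(F)c3)c(C)cc2=O)cc1` gives 4650 nM in a functional assay on NCI-H460 cells (Homo sapiens) for inhibition, read by MTT assay, with a stated time of 72 h (on this read-out higher numbers stand for weaker inhibition and lower numbers for stronger inhibition), the highest of the two numbers so far; its nearest neighbour, compound 1 `COc1cc2c(Oc3ccc(NC(=O)c4nn(-c5ccccc5OC(F)(F)F)c(=O)cc4C)cc3F)ccnc2cc1OCCCN1CCC(C)CC1`, gives 290 nM in this assay. For the measured compounds named here, the only measured step between them is a 16-fold higher number from compound 1 to compound 2 (1.21 log units; beyond the scatter), which shows that the aryl on the aromatic nitrogen moves the read-out strongly. Compound 3 `COc1cc2c(Oc3ccc(NC(=O)c4nn(-c5ccc(Cl)cc5Cl)c(=O)cc4C)cc3F)ccnc2cc1OCCCN1CCC(C)CC1` differs from compound 2 by 2,4-dichlorophenyl in place of 4-methoxyphenyl on an aromatic nitrogen. Going by the values given here, no measured pair covers the 2,4-dichlorophenyl group, so the expectation rests only on compound 1 and compound 2: an aryl change at this position has produced a large step, and compound 1, with a 2-(trifluoromethoxy)phenyl group, sits far below compound 2. For compound 3 a lower number than for compound 2 is therefore expected, with the step estimated at a 7.8-fold lower number from compound 2 to compound 3 (0.89 log units; beyond the scatter). The estimate for compound 3 in this assay is 600 nM, with a range from 150 nM to 2500 nM.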

Compound 3, half-maximal inhibitory concentration: 250 nM
Compound 3: the middle estimate sits 2.4-fold (0.38 log units) above what was measured; low and high end bracket the measured number.
By their numbers in this assay, from the lowest: compounds 3 and 1 (each within the scatter of the next); then compound 2.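

In this assay the change to 2,4-dichlorophenyl gives a 19-fold lower number from compound 2 to compound 3 (1.27 log units; beyond the scatter) and shows that the low level of compound 1 is not tied to the 2-(trifluoromethoxy)phenyl group. Replacing that group with 2,4-dichlorophenyl gives a 1.2-fold lower number from compound 1 to compound 3 (0.06 log units; within the scatter) and stays within the scatter, so two differently substituted aryl groups on the aromatic nitrogen read alike. Of the three aryl groups shown, only 4-methoxyphenyl stands apart, so the high number belongs to compound 2 alone and not to aryl exchange at this position in general.

Still open, from the compounds shown here alone, is whether the methoxy group itself or its placement sets compound 2 apart: 2-methoxyphenyl, 4-chlorophenyl or unsubstituted phenyl on the same nitrogen would separate the two, and cyclohexyl would test the need for an aromatic ring. Nothing in hand explains why these aryl groups differ.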